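The source may hold more compounds than are shown below. What is called first, only, known or untested is meant among the compounds shown, and "the series" means these compounds.

Measured compounds in an assay on isolated protein for agonist activity at Free fatty acid receptor 1 (Homo sapiens); on this read-out higher numbers stand for an effect only at larger amounts of compound and lower numbers for an effect already at smaller amounts:
- compound 1, `CC#CC(CC(=O)O)c1ccc(OCc2ccn3cc(-c4ccc(C)cc4)nc3c2)cc1`: 618 nM
- compound 2, `CC#CC(CC(=O)O)c1ccc(OCc2ccn3cc(-c4ccc(CC)cc4)nc3c2)cc1`: 671 nM
- compound 3, `CC#CC(CC(=O)O)c1ccc(OCc2ccn3cc(-c4ccccc4C)nc3c2)cc1`: 459 nM

Compound 3 holds the lowest of the three numbers, yet the gaps are small: a 1.3-fold lower number from compound 1 to compound 3 (0.13 log units; within the scatter) and a 1.5-fold lower number from compound 2 to compound 3 (0.16 log units; within the scatter), so the three compounds are not told apart in this assay.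

Compound 4, `CC#CC(CC(=O)O)c1ccc(OCc2ccn3cc(-c4ccc(F)cc4)nc3c2)cc1`, differs from compound 3 in one place: 4-fluorophenyl in place of 2-methylphenyl on an aromatic carbon. Within the data shown here, the steps that bear on this change are those that also swap the group at the same place, a 1.3-fold lower number from compound 1 to compound 3 (0.13 log units; within the scatter) and a 1.5-fold lower number from compound 2 to compound 3 (0.16 log units; within the scatter), both within the scatter. A further swap at this place is therefore expected to give no step beyond the scatter, a 1.2-fold higher number from compound 3 to compound 4 (0.08 log units; within the scatter). Compound 4 is estimated at 550 nM, with a range from 250 nM to 1200 nM.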

Compound 4, half-maximal effective concentration: 783 nM
Compound 4: the middle estimate sits 1.4-fold (0.15 log units) below what was measured; the measured number falls inside the stated range.
By their numbers in this assay, from the lowest: compounds 3, 1, 2 and 4 (each within the scatter of the next).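

In this assay the swap to 4-fluorophenyl gives a 1.7-fold higher number from compound 3 to compound 4 (0.23 log units; within the scatter) and the swaps to fluoro give a 1.2-fold higher number from compound 2 to compound 4 (0.07 log units; within the scatter) and a 1.3-fold higher number from compound 1 to compound 4 (0.10 log units; within the scatter) so a fourth group at this place still cannot be told apart from the others. A fluoro group on the phenyl ring therefore joins methyl and ethyl with no step beyond the scatter. Nothing measured here offers an explanation for these small steps. Going by these compounds, whether an amine or a carboxylic acid on the phenyl ring would give a step beyond the scatter stays open.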